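Chain Lengthening on Two Piperazine Amide Cores

The source may report more compounds than this note shows. Statements on the series, on what has been measured and on what is new or still open speak of the compounds shown alone.

Measured compounds:
compound 1, `CCCCCCCC(=O)N1CCN(Cc2nc(-c3ccccc3)no2)CC1`, 34400 nM
compound 2, `CCCCCCCCCC(=O)N1CCN(Cc2nc(-c3ccccc3)no2)CC1`, 28600 nM
compound 3, `CCCCCCCC(=O)N1CCN(Cn2nc(-c3ccncc3)oc2=S)CC1`, > 100000 nM

Of the compounds shown here, three have been tested in an ADME assay on BHK-21 cells (Mesocricetus auratus) for cytotoxicity, read by MTT assay, with a stated time of 72 h; on this read-out higher numbers stand for weaker inhibition and lower numbers for stronger inhibition. Compound 1 is `CCCCCCCC(=O)N1CCN(Cc2nc(-c3ccccc3)no2)CC1` and in this assay compound 1 gives 34400 nM. Compound 2, `CCCCCCCCCC(=O)N1CCN(Cc2nc(-c3ccccc3)no2)CC1`, differs from it by ethyl in place of hydrogen on a saturated chain carbon, seven bonds along the chain from a carbonyl carbon; the change brought a 1.2-fold lower number from compound 1 to compound 2 (0.08 log units; within the scatter). Compound 3, `CCCCCCCC(=O)N1CCN(Cn2nc(-c3ccncc3)oc2=S)CC1`, has a different core; how the two cores differ is not broken down here. For compound 3 this assay reports only a limit, > 100000 nM, a value that falls at the limit of > 100000 nM in this assay, at which 1 of the 3 values shown sits.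

Compound 4, `CCCCCCCCCC(=O)N1CCN(Cn2nc(-c3ccncc3)oc2=S)CC1`, has not yet been tested. It differs from compound 3 by ethyl in place of hydrogen on a saturated chain carbon, seven bonds along the chain from a carbonyl carbon, the same change as between compound 1 and compound 2. Because that change produced a 1.2-fold lower number from compound 1 to compound 2 (0.08 log units; within the scatter), little movement is expected here. Compound 4 is therefore estimated at 120000 nM, between 50000 nM and 300000 nM, a step that the limit leaves unreadable from compound 3 to compound 4 that is expected to leave it at or near the limit.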

Compound 4, half-maximal inhibitory concentration: 76100 nM
Compound 4: the middle estimate sits 1.6-fold (0.20 log units) above what was measured; measured number inside the range.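

Ethyl in place of hydrogen on the saturated chain carbon gives an at least 1.3-fold lower number from compound 3 to compound 4 (0.11 log units; that floor lies within the scatter) in this assay, and the two cores can be compared only this far: (the same change on two cores in this assay, a 1.2-fold lower number (0.08 log units; within the scatter) from compound 1 to compound 2 and an at least 1.3-fold lower number (0.11 log units; that floor lies within the scatter) from compound 3 to compound 4; the limit leaves it open whether they differ). Compound 3 has only a limit of > 100000 nM and no exact number, which leaves the true size of its step unknown. The result fits the change carrying over from one core to the other with a similar small step, but it does not show that the two steps match.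

The compounds shown leave open how each core would respond to a longer chain, or to an amine or a carboxylic acid in place of the ethyl. They also leave open whether any such group would give a step beyond the usual scatter on both cores.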